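The source may hold more compounds than are shown below. What is called first, only, known or untested is meant among the compounds shown, and "the series" means these compounds.

Measured so far in a functional assay on A498 cells (Homo sapiens) for inhibition, read by sulforhodamine B assay, with a stated time of 48 h, tested at 10 uM; on this read-out lower numbers stand for a stronger effect and higher numbers for a weaker effect at the one concentration tested:
compound 1, `COc1cc(Cl)cc(-c2nn(-c3cccc(NC(=O)c4ccc(Cl)c(Cl)c4)c3)cc2-c2ccncc2)c1`, gives -0.94%
compound 2, `O=C(Nc1cccc(-n2cc(-c3ccncc3)c(-c3cc(O)cc(Cl)c3)n2)c1)Nc1ccc(Cl)c(Cl)c1`, gives -2.98%
compound 3, `COc1cc(Cl)cc(-c2nn(-c3cccc(NC(=O)Nc4ccc(Cl)c(C(F)(F)F)c4)c3)cc2-c2ccncc2)c1`, gives -9.18%

All three numbers sit close to zero. Compound 3 has the lowest of the three, but its nearest neighbour is compound 2, a number only slightly higher and within the scatter, and even the furthest, compound 1, lies within the scatter, so no ranking among the three can be drawn.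

The next compound, compound 4, is `COc1cc(Cl)cc(-c2nn(-c3cccc(NC(=O)Nc4ccc(Cl)c(Cl)c4)c3)cc2-c2ccncc2)c1`. It differs from compound 3 by chloro in place of trifluoromethyl on an aromatic carbon. Going by the values given here, only one measured step touches this part of the molecule: a number 8.2 percentage points lower from compound 1 to compound 3 (within the scatter), which combines the entry of the amino link with the exchange of chloro for trifluoromethyl, and it stayed within the scatter. Compound 4 carries the amino link of compound 3 and the 3,4-dichlorophenyl of compound 1, whose values in this assay differ by a margin inside the scatter. Nothing here points to a step in either direction beyond the scatter, so compound 4 is expected to land close to compound 3, with an expected step of a number 4.2 percentage points higher from compound 3 to compound 4 (within the scatter). The estimate for compound 4 in this assay is therefore -5%, with a likely range from -16% to 6%.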

Compound 4, a percentage reported as activity, at one concentration (the size of the read-out at that concentration, not a potency): -9.54%
Compound 4: the middle estimate sits 4.5 percentage points above what was measured, within the range that was stated.
By their numbers in this assay, from the lowest: compounds 4, 3, 2 and 1 (each within the scatter of the next).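

In this assay, going by these compounds alone, the exchange of trifluoromethyl for chloro on this aromatic carbon, ortho to a chloro group and meta to a large group, now stands alone for the first time: the step of a number 0.4 percentage points lower from compound 3 to compound 4 (within the scatter) shows no separation between the two groups at this position, whereas the earlier step to compound 3 also carried the entry of the amino link. The entry of that link is now also isolated, with the 3,4-dichlorophenyl held constant, in the step of a number 8.6 percentage points lower from compound 1 to compound 4 (within the scatter) and does not separate either, and the same holds for methyl in place of hydrogen on the oxygen, in the step of a number 6.6 percentage points lower from compound 2 to compound 4 (within the scatter) on the other side of the molecule. No data are at hand to explain any of these results.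

Open, on these data alone, is what a carboxylic acid, an amine or a longer chain such as propyl on this aromatic carbon would do to the read-out, and whether any group here can separate from the scatter. Also open, as far as these compounds go, is whether the exchange of trifluoromethyl for chloro reads the same with the free hydroxyl of compound 2 in place of the methoxy group.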